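The source may hold more compounds than are shown below. What is called first, only, known or untested is meant among the compounds shown, and "the series" means these compounds.

The shared core appears in compound 1, `CC(=O)c1ccc(NC(=O)CSc2nc3c(c(=O)n2-c2ccccc2)SCC3)cc1`, whose value in an assay on L cells for inhibition of Protein-serine O-palmitoleoyltransferase porcupine (Mus musculus), read by reporter gene assay, with a stated time of 24 h (on this read-out higher numbers stand for an effect only at larger amounts of compound and lower numbers for an effect already at smaller amounts), is only a limit: compound 1 gives > 1000 nM, a limit rather than a number. Compound 2, `O=C(CSc1nc2c(c(=O)n1-c1ccccc1)SCC2)Nc1ccc(-c2cccs2)cn1`, carries a different amide substituent on the same core, and in this assay compound 2 gives 0.3 nM. Compound 1 therefore stands at the limit of > 1000 nM in this assay, at which 1 of the 2 values shown sits, while compound 2 sits far from it; with no numeric value for compound 1, only this much can be said of the pair.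

Compound 3, `CCOc1ccc(NC(=O)CSc2nc3c(c(=O)n2-c2ccccc2)SCC3)cc1`, is compound 1 with ethoxy in place of acetyl on an aromatic carbon. The ethoxy group enters on the same aromatic carbon of the six-membered carbon-only ring, para to the large group, that the acetyl group leaves. Among the compounds with values here, no measured step between two compounds of this set helps to weigh such a change, so the expectation rests on compound 1 alone. Compound 3 is expected to show no step beyond the scatter in this assay, the step from compound 1 to compound 3 being estimated as a step that the limit leaves unreadable from compound 1 to compound 3. Compound 3 is thus estimated at 3000 nM, with a range from 300 nM to 30000 nM.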

Compound 3, half-maximal effective concentration: 1000 nM
Compound 3: the middle estimate sits 3.0-fold (0.48 log units) above what was measured; the measured number falls inside the stated range.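

Compound 3, with ethoxy on the aromatic carbon para to a large group, gives 1000 nM in this assay, so this position now has a measured number. The two groups match in their counts of heavy atoms and hydrogen-bond acceptors and differ in that acetyl carries a double bond outside aromatic rings, yet the size of this exchange stays out of reach. Ethoxy in place of acetyl gives a number no higher from compound 1 to compound 3 (the limit leaves the size open), and this step cannot be read, because compound 1 stands at a limit and not at a number: the limit of > 1000 nM in this assay, at which 1 of the 3 values shown sits.

Going by these compounds, how far the value of compound 1 lies past that limit remains open, and with it whether ethoxy in place of acetyl changes anything at this position at all. Also open, on these data alone, is how a methoxy group, a longer chain such as propoxy, an amine or a carboxylic acid on this same aromatic carbon would read in this assay.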